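Phenyl to Pyrrolidin-1-yl: an Expected Shift in Potency

This account rests on a few compounds, and the source may have more. Where it says the series, first, only, none or still open, it means among the compounds named here.

Of the compounds shown here, three have been measured in a functional assay for inhibition of sodium/hydrogen exchanger (Oryctolagus cuniculus); a lower number here means a stronger inhibitor, a higher number a weaker inhibitor. Compound 1 `Cc1c(C(=O)N=C(N)N)ccc(Cl)c1S(C)(=O)=O` gives 1300 nM, compound 3 `COc1cc(Cl)c(C(=O)N=C(N)N)cc1S(C)(=O)=O` gives 40 nM, and compound 2 `Cc1cc(-c2ccccc2)c(S(C)(=O)=O)cc1C(=O)N=C(N)N` gives 19 nM. Compound 2 thus shows the lowest number of the three and is the strongest inhibitor here; its gap to compound 3 is the smaller one and its gap to compound 1 the larger, and both lie beyond the usual scatter. Compound 4 `Cc1cc(N2CCCC2)c(S(C)(=O)=O)cc1C(=O)N=C(N)N` has not yet been measured. It differs from compound 2 in one place: pyrrolidin-1-yl in place of phenyl on an aromatic carbon. Among the compounds with values here, no measured pair shows this same change, so its effect is uncertain. For compound 4 the number is expected to rise modestly, a step of a 2.6-fold higher number from compound 2 to compound 4 (0.42 log units; beyond the scatter). The estimate for compound 4 is 50 nM, with a range from 15 nM to 200 nM.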

Compound 4, half-maximal inhibitory concentration: 11 nM
The estimate for compound 4 lay 4.5-fold (0.66 log units) above the measured number, outside the stated range (below it).
By their numbers in this assay, from the lowest: compounds 4 and 2 (each within the scatter of the next); then compound 3; then compound 1.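

At the aromatic carbon ortho to a methylsulfonyl group, pyrrolidin-1-yl in place of phenyl gives a 1.7-fold lower number from compound 2 to compound 4 (0.24 log units; within the scatter) in this assay for this pair, so the two compounds cannot be told apart. This position therefore tolerates both a six-membered aromatic ring of carbon only and a five-membered non-aromatic ring containing nitrogen, though this rests on a single pair. Nothing shown gives a reason for this result.

On these data alone, whether an open-chain amine such as dimethylamino would match these two rings remains open. So does the outcome with a larger ring such as piperidine or morpholine at this position.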